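This account rests on a few compounds, and the source may have more. Where it says the series, first, only, none or still open, it means among the compounds named here.

Compound 1 `O=C(O)CCc1ccncc1-c1ccc2ccccc2c1` is the reference point of this account. Among the measured compounds shown here, in an assay on a protein complex for inhibition of CDK8/Cyclin C (Homo sapiens), with a stated time of 1 h (on this read-out lower numbers stand for stronger inhibition and higher numbers for weaker inhibition), compound 1 gives 50.5 nM, which is the higher of the two numbers known so far. Its companion compound 2 `O=C(CCc1ccncc1-c1ccc2ccccc2c1)N1CCOCC1`, in which a morpholin-4-yl stands in place of the hydroxy on the carbonyl carbon, gives 45.5 nM in this assay, and the step of a 1.1-fold lower number from compound 1 to compound 2 (0.05 log units; within the scatter) lies within the scatter, so the two cannot be ordered. A third member of the set, compound 3 `O=C(/C=C/c1ccncc1-c1ccc2cccnc2c1)N1CCOCC1`, stands in this assay as "not determined" (no result reported), so it adds nothing to the numbers.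

The step followed here leads from compound 1 to compound 4 `O=C(O)/C=C/c1ccncc1-c1ccc2ccccc2c1`. The change is 2-carboxyethenyl in place of 2-carboxyethyl on an aromatic carbon. For the measured compounds named here, the only measured step in the set concerns the carbonyl end of the same chain and says nothing about the chain between the ring and the carbonyl, so no measured step bears directly on this change. With nothing in the data pointing either way, the step in this assay is expected to stay within the scatter. On that basis compound 4 is expected to give 50 nM, with a range from 20 nM to 125 nM, which corresponds to an expected step of a 1.0-fold lower number from compound 1 to compound 4 (0.00 log units; within the scatter).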

Compound 4, half-maximal inhibitory concentration: 5 nM
Compound 4: middle estimate off by 10-fold (1.00 log units), on the high side, outside the stated range (below it).
By their numbers in this assay, from the lowest: compound 4; then compounds 2 and 1 (each within the scatter of the next).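

The chain between the ring and the carbonyl proves to be a place where the number responds. Among the compounds shown here, with the heavy-atom count unchanged and one more double bond outside aromatic rings, 2-carboxyethenyl in place of 2-carboxyethyl on the aromatic carbon opposite the ring nitrogen gives a 10-fold lower number from compound 1 to compound 4 (1.00 log units; beyond the scatter) in this assay, whereas the only step read earlier, a 1.1-fold lower number from compound 1 to compound 2 (0.05 log units; within the scatter) at the carbonyl end of the chain, had stayed within the scatter. No measurement in hand accounts for this gain, so it stands as an observation about this single change.

Still open, as far as these compounds go, is whether the 2-carboxyethenyl chain keeps its number when morpholin-4-yl stands in place of the hydroxy on the carbonyl carbon, a swap that stayed within the scatter on the 2-carboxyethyl chain, as compound 3 carries such an amide on a different core and offers no number. Open too, from the compounds shown here alone, is how other chains at this position would read, such as one with a carbon-carbon triple bond in place of the double bond, or a longer chain ending in a carboxylic acid.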